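This account rests on a few compounds, and the source may have more. Where it says the series, first, only, none or still open, it means among the compounds named here.

Compound 1 `COc1cc(-c2nnc3c(OC(C)C)cc(-c4ccc5[nH]ccc5c4)cn23)cc(OC)c1OC` gives 939 nM in a functional assay on HCT-116 cells (Homo sapiens) for antiproliferative activity, read by MTT assay, with a stated time of 48 h; on this read-out lower numbers stand for stronger inhibition and higher numbers for weaker inhibition. Compound 2 `COc1cc(-c2nnc3c(OC4COC4)cc(-c4ccc5[nH]ccc5c4)cn23)cc(OC)c1OC` differs from it by oxetan-3-yl in place of isopropyl on an oxygen on an aromatic ring, and in this assay compound 2 gives 5370 nM, so that a 5.7-fold higher number from compound 1 to compound 2 (0.76 log units; beyond the scatter). Compound 3 `COc1cc(-c2nnc3c(OC(C)C)cc(-c4ccc5c(ccn5C)c4)cn23)cc(OC)c1OC` differs from compound 1 by methyl in place of hydrogen on an aromatic nitrogen; in this assay compound 3 gives 402 nM, so that a 2.3-fold lower number from compound 1 to compound 3 (0.37 log units; beyond the scatter). Compound 4 `COc1cc(-c2nnc3c(OC4COC4)cc(-c4ccc5c(ccn5C)c4)cn23)cc(OC)c1OC` has not been measured; it differs from compound 3 by oxetan-3-yl in place of isopropyl on an oxygen on an aromatic ring, the same change that separates compound 2 from compound 1. Because the first occurrence of this change gave a 5.7-fold higher number from compound 1 to compound 2 (0.76 log units; beyond the scatter), a step of similar size is expected here, namely a 5.7-fold higher number from compound 3 to compound 4 (0.76 log units; beyond the scatter), though this rests on a single earlier pair. Compound 4 is therefore estimated at 2300 nM in this assay, with a plausible range from 1000 nM to 5500 nM.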

Compound 4, half-maximal inhibitory concentration: 1290 nM
The estimate for compound 4 lay 1.8-fold (0.25 log units) above the measured number, and the stated range covers the measured number.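

Oxetan-3-yl in place of isopropyl again gave a higher number in this assay, with a 3.2-fold higher number from compound 3 to compound 4 (0.51 log units; beyond the scatter), and the two occurrences agree: the same change on two cores in this assay, a 5.7-fold higher number (0.76 log units; beyond the scatter) from compound 1 to compound 2 and a 3.2-fold higher number (0.51 log units; beyond the scatter) from compound 3 to compound 4, 1.8-fold (0.25 log units) apart, within the scatter of two such steps. Methyl in place of hydrogen on the aromatic nitrogen also carried over, giving a 4.2-fold lower number from compound 2 to compound 4 (0.62 log units; beyond the scatter), and this pair agrees as well: the same change on two cores in this assay, a 2.3-fold lower number (0.37 log units; beyond the scatter) from compound 1 to compound 3 and a 4.2-fold lower number (0.62 log units; beyond the scatter) from compound 2 to compound 4, 1.8-fold (0.25 log units) apart, within the scatter of two such steps. Each change thus kept its direction and a similar size across these two cores, but four compounds in one assay do not show that either step would hold on any other core.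

The compounds shown leave open how an amine or a longer chain on the same oxygen would compare with isopropyl. They also leave open what an ethyl group on the aromatic nitrogen would do.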